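Moving the amide around a pyridine ring in orexin-1 agonists

This account rests on a few compounds, and the source may have more. Where it says the series, first, only, none or still open, it means among the compounds named here.

Measured compounds:
compound 1 `COc1ccc(-c2cc(C(=O)N(C)C)ccn2)cc1S(=O)(=O)Nc1cccc(NCCNC(=O)c2cccc(C)c2)c1` — 1810 nM
compound 2 `COc1ccc(-c2cncc(C(=O)N(C)C)c2)cc1S(=O)(=O)Nc1cccc(NCCNC(=O)c2cccc(C)c2)c1` — 7530 nM
compound 3 `COc1ccc(-c2ccnc(C(=O)N(C)C)c2)cc1S(=O)(=O)Nc1cccc(NCCNC(=O)c2cccc(C)c2)c1` — 5170 nM

All three share one core and differ only in the pyridine that carries the dimethylcarbamoyl group. In a functional assay on CHO-RD-HGA16 cells for agonist activity at Orexin/Hypocretin receptor type 1 (Homo sapiens), read by fluorescence and calcium flux, with a stated time of 30 min (on this read-out lower numbers stand for an effect already at smaller amounts and higher numbers for an effect only at larger amounts of compound), compound 1 gives 1810 nM, the lowest number of the set; compound 3 stands second highest, with a 1.5-fold lower number from compound 2 to compound 3 (0.16 log units; within the scatter) between it and compound 2 and a 2.9-fold higher number from compound 1 to compound 3 (0.46 log units; beyond the scatter) separating it from compound 1.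

Compound 4 `COc1ccc(-c2cccc(C(=O)N(C)C)n2)cc1S(=O)(=O)Nc1cccc(NCCNC(=O)c2cccc(C)c2)c1` is not yet measured. It differs from compound 3 in that (6-(dimethylcarbamoyl)pyridin-2-yl in place of 2-(dimethylcarbamoyl)pyridin-4-yl on an aromatic carbon). The change brings back the attachment pattern of compound 1, a pyridin-2-yl joined at the core, while the carboxamide sits on the opposite side of the ring nitrogen. Going by the values given here, the steps that bear on it are a 2.9-fold higher number from compound 1 to compound 3 (0.46 log units; beyond the scatter) and a 1.5-fold lower number from compound 2 to compound 3 (0.16 log units; within the scatter): the two non-2-yl isomers, compounds 2 and 3, sit close together, and only compound 1 is clearly lower. Whether the carboxamide at the 6-position repeats the behaviour of compound 1 cannot be read from these three compounds, so a partial return toward compound 1 is expected: compound 4 is estimated to show a 2.0-fold lower number from compound 3 to compound 4 (0.30 log units; within the scatter). The estimate for compound 4 in this assay is 2600 nM, with a range from 1000 nM to 7000 nM.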

Compound 4, half-maximal effective concentration: 226 nM
The estimate for compound 4 lay 12-fold (1.06 log units) above the measured number; the whole stated range lies above it.
By their numbers in this assay, from the lowest: compound 4; then compound 1; then compounds 3 and 2 (each within the scatter of the next).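

In this assay, the new result shows that the place of the carboxamide on the pyridine can matter far more than the first three compounds suggested, with a 23-fold lower number from compound 3 to compound 4 (1.36 log units; beyond the scatter) and a 33-fold lower number from compound 2 to compound 4 (1.52 log units; beyond the scatter). Joining the pyridine to the core as a pyridin-2-yl does not settle the outcome by itself: compounds 1 and 4 share that attachment, yet the change from 4-(dimethylcarbamoyl)pyridin-2-yl to 6-(dimethylcarbamoyl)pyridin-2-yl still gives an 8.0-fold lower number from compound 1 to compound 4 (0.90 log units; beyond the scatter). The two groups have the same atoms and the same counts, so this difference in this assay comes with a change in their arrangement alone, and no measurement at hand accounts for it.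

The compounds shown leave open whether the effect depends on the dimethylcarbamoyl group itself, since a carboxylic acid, a primary carboxamide or a pyrrolidine amide does not appear in that place. Going by these compounds alone, they also leave open whether the ring nitrogen is needed, as no compound here carries the same dimethylcarbamoyl group on a plain phenyl ring.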